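The source may hold more compounds than are shown below. What is called first, only, known or untested is meant among the compounds shown, and "the series" means these compounds.

In a physicochemical assay for solubility, read by HPLC, in phosphate buffer, with a stated time of 24 h, at pH 7.4, tested at 100 uM (on this read-out lower numbers stand for lower solubility and higher numbers for higher solubility), compound 1 (`O=C(CCCCCNc1c(NCc2ccccc2)c(=O)c1=O)NO`) gives 75000000 nM and compound 2 (`O=C(CCCCCNc1c(NC2CCCCC2)c(=O)c1=O)NO`) gives 91000000 nM in the same measurement. Among the measured compounds shown here, these are the only two measured compounds, and they stand level within the scatter. Compound 3 (`Cc1ccccc1Nc1c(NCCCCCC(=O)NO)c(=O)c1=O`) carries 2-methylphenyl in place of cyclohexyl on a nitrogen on an aromatic ring and is still unmeasured. For the measured compounds named here, only one measured step bears on this change. It is a 1.2-fold higher number from compound 1 to compound 2 (0.08 log units; within the scatter) for cyclohexyl in place of benzyl at the same place, and it stays within the scatter. Going by the values given here, that single step suggests that exchanging these groups need not move the number much, though no measured compound yet carries 2-methylphenyl. The estimated step is a 1.7-fold lower number from compound 2 to compound 3 (0.22 log units; within the scatter) in this assay and is expected to stay within the scatter, leaning slightly toward a lower number. Compound 3 is expected at 55000000 nM (estimated range 20000000 nM to 110000000 nM).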

Compound 3, solubility: 89000000 nM
Compound 3: the middle estimate sits 1.6-fold (0.21 log units) below what was measured, within the range that was stated.
By their numbers in this assay, from the lowest: compounds 1, 3 and 2 (each within the scatter of the next).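

In this assay, 2-methylphenyl in place of cyclohexyl on a nitrogen on an aromatic ring gives a 1.0-fold lower number from compound 2 to compound 3 (0.01 log units; within the scatter) and stays level with its neighbour, while 2-methylphenyl in place of benzyl gives a 1.2-fold higher number from compound 1 to compound 3 (0.07 log units; within the scatter) and also stays level. The earlier pair held only a benzyl and a cyclohexyl group, whereas compound 3 shows that a six-membered aromatic ring of carbon only, carrying a methyl group and joined directly to this nitrogen, also leaves the number within the scatter of both. Nothing shown explains why these three groups read alike.

All three groups are built of carbon only, with no hydrogen-bond donors or acceptors and no net charge. Going by these compounds, whether an amine or a carboxylic acid on this nitrogen would move the number beyond the scatter stays open, as does the effect of a longer chain on the other nitrogen.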